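A few compounds are considered here, and "the series" means these few. Any claim that something is new, unique, unknown or untested is made for them only; others in the source may bear on it.

So far, two compounds have been measured in an ADME assay on microsomes from liver (Rattus norvegicus, strain Sprague-Dawley) for metabolic stability, read by HPLC, using NADPH, with stated times of 5 min and 60 min, tested at 10 uM; a lower number here means slower removal, a higher number faster removal of the compound: compound 2 (`CCOc1ccc(C(=O)NCc2ccc(NS(C)(=O)=O)cc2Cl)cc1`) gives 12 mL.min-1.g-1 and compound 1 (`CS(=O)(=O)Nc1ccc(CNC(=O)c2ccc(C3(C(F)(F)F)CC3)cc2)c(Cl)c1`) gives 7.5 mL.min-1.g-1 on the same scale. These two numbers lie within the usual scatter of each other, so neither can be ranked against the other. Compound 3 (`CC(F)(F)c1ccc(C(=O)NCc2ccc(NS(C)(=O)=O)cc2Cl)cc1`) differs from compound 2 in one place, with 1,1-difluoroethyl in place of ethoxy on an aromatic carbon, para to a large group (1,1-difluoroethyl in place of ethoxy on an aromatic carbon). Among the measured compounds shown here, the only measured step that bears on this change also involves ethoxy on an aromatic carbon, where ethoxy in place of 1-(trifluoromethyl)cyclopropyl gives a 1.6-fold higher number from compound 1 to compound 2 (0.20 log units; within the scatter) and nothing larger. Going by that single small step, the expected change in this assay is a 1.2-fold lower number from compound 2 to compound 3 (0.08 log units; within the scatter) and no clear move beyond the scatter. For compound 3 the estimated value is 10 mL.min-1.g-1 (expected range 5 mL.min-1.g-1 to 19 mL.min-1.g-1).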

Compound 3, intrinsic clearance in microsomes: 9.6 mL.min-1.g-1
Estimate against measurement, compound 3: 1.0-fold (0.02 log units) above; measured number inside the range.
By their numbers in this assay, from the lowest: compounds 1, 3 and 2 (each within the scatter of the next).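

In this assay, putting 1,1-difluoroethyl in place of ethoxy on the aromatic carbon para to a large group gives a 1.3-fold lower number from compound 2 to compound 3 (0.10 log units; within the scatter), and putting it in place of 1-(trifluoromethyl)cyclopropyl at that same place gives a 1.3-fold higher number from compound 1 to compound 3 (0.11 log units; within the scatter). Three different groups, one carrying oxygen and two carrying fluorine, have now been compared at this one position, and their numbers cannot be told apart on this scale. Nothing available explains why these numbers stay so close.

Going by these compounds, it remains open whether any group at this position can move the number beyond the scatter, for example an amine, a carboxylic acid or a longer chain. On these data alone, it is also open whether the same closeness would hold on a different core.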